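The compounds below may be only part of what the source reports. "The series", "measured", "known", "first", "only" and "open" are said of these compounds alone.

Of the compounds shown here, three have so far been measured in an assay on HEK293 cells for inhibition of transient receptor potential cation channel subfamily M member 8 (Homo sapiens), read by FLIPR, with stated times of 5 min and 3 min; on this read-out higher numbers stand for weaker inhibition and lower numbers for stronger inhibition. Compound 1 `O=C(c1sc(-c2cccc(F)c2)nc1O)N1CCCOC1` gives > 100000 nM, which is a limit of the assay rather than a number. Compound 2 `CCOC(=O)c1cnc(-c2ccccc2)s1` likewise gives > 100000 nM, again a limit and not a true value. Compound 3 `CCn1nnc(-c2sc(-c3ccccc3OC)nc2O)n1` gives 2790 nM. On these data alone, compound 2 therefore stands at the limit of > 100000 nM in this assay, at which 2 of the 3 values shown sit, so its real strength is unknown beyond that point. Compound 4 `CCOC(=O)c1sc(-c2ccccc2)nc1N` differs from compound 2 by amino in place of hydrogen on an aromatic carbon. Among the measured compounds shown here, no measured pair in this set shows what such a change does, so only a cautious guess is possible. Compound 4 is expected to give about 80000 nM, most likely between 15000 nM and 400000 nM. The expected step is an at least 1.2-fold lower number from compound 2 to compound 4 (0.09 log units; that floor lies within the scatter), which may well be nothing beyond the usual scatter.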

Compound 4, half-maximal inhibitory concentration: > 100000 nM
Compound 4: a limit, no number; the forecaster's own chance of this, stated with the estimate: 60%; at least 1.2-fold (0.09 log units) between middle value and limit.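

Compound 4 gives > 100000 nM, a limit and not a number. Among the compounds shown here, compound 2 is also a limit, so no step between them can be read. On these data alone, whether amino in place of hydrogen changes inhibition stays open.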